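The source may hold more compounds than are shown below. What is called first, only, known or untested is meant among the compounds shown, and "the series" means these compounds.

Compound 1 `C#CCNC(=O)c1ccc(C(CC)(CC)c2ccc(OCC(=O)C(C)(C)C)c(C)c2)n1CC`: 2200 nM
Compound 2 `CCn1c(C(=O)N(C)c2ccccc2)ccc1C(CC)(CC)c1ccc(OCC(=O)C(C)(C)C)c(C)c1`: 18500 nM
Compound 3 `CCn1c(C(=O)N(CCC#N)CCC#N)ccc1C(CC)(CC)c1ccc(OCC(=O)C(C)(C)C)c(C)c1`: 870 nM

In an assay on HL-60 cells for agonist activity at vitamin D3 receptor (Homo sapiens), read by microscopy, with a stated time of 96 h (on this read-out higher numbers stand for an effect only at larger amounts of compound and lower numbers for an effect already at smaller amounts), compound 3 gives 870 nM, the lowest of the three numbers, with compound 1 nearest and compound 2 furthest. Compound 4 `CCOc1ccc(NC(=O)c2ccc(C(CC)(CC)c3ccc(OCC(=O)C(C)(C)C)c(C)c3)n2CC)cc1` differs from compound 3 by a group of 10 heavy atoms (8 carbon, 1 nitrogen, 1 oxygen; one six-membered aromatic ring of carbon only) in place of a group of 9 heavy atoms (6 carbon, 3 nitrogen; no ring), on a carbonyl carbon. Among the measured compounds shown here, two measured steps bear on this change: a 21-fold lower number from compound 2 to compound 3 (1.33 log units; beyond the scatter) and a 2.5-fold lower number from compound 1 to compound 3 (0.40 log units; beyond the scatter). In both, the number fell when the group of 9 heavy atoms entered, most strongly where an aromatic ring left. Reversing that, compound 4 is expected to show a higher number in this assay, beyond the scatter, though compound 4 keeps one hydrogen-bond donor as compound 1 does, and compound 1 gives 2200 nM, far below compound 2. Compound 4 is therefore estimated at 4000 nM (range 1200 nM to 14000 nM), a step of a 4.6-fold higher number from compound 3 to compound 4 (0.66 log units; beyond the scatter).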

Compound 4, half-maximal effective concentration: > 50000 nM
Compound 4: no number, only a limit (the forecaster's own chance of this, stated with the estimate: 5%); middle value at least 12-fold (1.09 log units) from the limit.
By their numbers in this assay, from the lowest: compound 3; then compound 1; then compound 2. At a limit, above all of these: compound 4.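

Compound 4 has no number, only a limit of the assay: the limit of > 50000 nM in this assay, at which 1 of the 4 values shown sits. With 4-ethoxyphenyl on the amide-type nitrogen, the change gives an at least 22-fold higher number from compound 1 to compound 4 (1.35 log units; beyond the scatter), so the amide hydrogen that compound 4 shares with compound 1 does not by itself keep the number low. The other two steps, an at least 2.7-fold higher number from compound 2 to compound 4 (0.43 log units; beyond the scatter) and an at least 57-fold higher number from compound 3 to compound 4 (1.75 log units; beyond the scatter), leave both compounds with an aromatic ring at this place, compound 2 and compound 4, highest of the four.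

The compounds shown leave open whether the ethoxy group or the ring itself carries this change. A plain phenylamino or a benzylamino group on the same carbonyl carbon could separate the two.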